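This account rests on a few compounds, and the source may have more. Where it says the series, first, only, none or still open, it means among the compounds named here.

Of the compounds shown here, three sharing one core have been measured in a functional assay on HUVEC cells (Homo sapiens) for inhibition, with a stated time of 4 days; a lower number here means a stronger inhibitor, a higher number a weaker inhibitor. Compound 1 `COc1ccc(C(N)=O)cc1/C=C/c1ccc(Cl)cc1` gives 87 nM, compound 2 `COc1ccc(C(N)=O)cc1/C=C/c1ccccc1F` gives 2000 nM, and compound 3 `COc1ccc(C(N)=O)cc1/C=C/c1ccc(Cl)cc1Cl` gives 2600 nM. Compound 3 thus sits at the high end of this small set, level within the scatter with compound 2 and far from compound 1.

The next structure, compound 4 `COc1ccc(C(N)=O)cc1/C=C/c1ccc(Cl)cc1F`, differs from compound 3 at one place: fluoro in place of chloro on an aromatic carbon. This is fluoro in place of chloro on an aromatic carbon, ortho to a large group. Among the compounds with values here, the one measured step that bears on it is large, a 30-fold higher number from compound 1 to compound 3 (1.48 log units; beyond the scatter), and it came with chloro in place of hydrogen on that same carbon. Compound 4 carries neither that hydrogen nor that chloro, so part of the step may be undone. Compound 2 also has fluoro on that carbon, though without the other chloro, and its 2000 nM argues against expecting a full return. The expected change is a moderate fall, a 5.2-fold lower number from compound 3 to compound 4 (0.72 log units; beyond the scatter). For compound 4 the estimated value is 500 nM, with an expected range of 120 nM to 2200 nM.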

Compound 4, half-maximal inhibitory concentration: 1700 nM
Compound 4: the middle estimate sits 3.4-fold (0.53 log units) below what was measured; the range from low to high includes it.
By their numbers in this assay, from the lowest: compound 1; then compounds 4, 2 and 3 (each within the scatter of the next).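

In this assay, fluoro and chloro on this carbon, ortho to a large group, cannot be told apart: a 1.5-fold lower number from compound 3 to compound 4 (0.18 log units; within the scatter). The loss seen with chloro in place of hydrogen on this carbon also appears with fluoro, which gives a 20-fold higher number from compound 1 to compound 4 (1.29 log units; beyond the scatter), so it is not particular to chloro. Adding chloro to compound 2 has no clear effect, giving a 1.2-fold lower number from compound 2 to compound 4 (0.07 log units; within the scatter), and the same listed change therefore behaves differently on the two cores: the same change on two cores in this assay, a 30-fold higher number (1.48 log units; beyond the scatter) from compound 1 to compound 3 and a 1.2-fold lower number (0.07 log units; within the scatter) from compound 2 to compound 4, 35-fold (1.55 log units) apart, beyond the scatter of two such steps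

On these data alone, it remains open whether any group on this carbon other than hydrogen gives the same loss, as a methyl group, a hydroxyl or an amine there would test. These compounds also cannot show whether compound 1's advantage depends on the chloro group it carries.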